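The compounds below may be only part of what the source reports. "The series", "measured", "known", "first", "only" and "open" are said of these compounds alone.

Of the compounds shown here, three with the same core have been tested in a functional assay on NCI-H460 cells (Homo sapiens) for inhibition, read by sulforhodamine B assay, with a stated time of 72 h (a higher number here means a weaker inhibitor, a lower number a stronger inhibitor), and they differ only in the amine group on a saturated chain carbon bound to an aromatic carbon. Compound 2 `CCNC(=O)c1nnn(-c2cc(C(C)C)c(O)cc2O)c1-c1ccc(CN(CC)CC)cc1` gives 11 nM, compound 1 `CCNC(=O)c1nnn(-c2cc(C(C)C)c(O)cc2O)c1-c1ccc(CN2CCC[C@H](O)C2)cc1` gives 70 nM and compound 3 `CCNC(=O)c1nnn(-c2cc(C(C)C)c(O)cc2O)c1-c1ccc(CN2CCNCC2)cc1` gives 250 nM. Compound 3 thus has the highest number of the three, which makes it the weakest inhibitor so far.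

The next compound is compound 4 `CCNC(=O)c1nnn(-c2cc(C(C)C)c(O)cc2O)c1-c1ccc(CNC2CCCCC2)cc1`, which carries cyclohexylamino in place of piperazin-1-yl. The ring stays six-membered but is now of carbon only: cyclohexylamino in place of piperazin-1-yl on a saturated chain carbon bound to an aromatic carbon.

Among the measured compounds shown here, two measured steps bear on this change. Each ends on the piperazin-1-yl group. One is modest, a 3.6-fold higher number from compound 1 to compound 3 (0.55 log units; beyond the scatter), and the other is large, a 23-fold higher number from compound 2 to compound 3 (1.36 log units; beyond the scatter). Among these three compounds, none goes against the pattern that piperazin-1-yl gives the highest number. Cyclohexylamino itself has not been measured, so this is only indirect guidance. A clear drop in the number is therefore expected, of a size between those two steps. The expected change is an 8.3-fold lower number from compound 3 to compound 4 (0.92 log units; beyond the scatter). For compound 4 the estimated value is 30 nM, with an expected range from 9 nM to 100 nM.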

Compound 4, half-maximal inhibitory concentration: 15 nM
Compound 4: the middle estimate sits 2.0-fold (0.30 log units) above what was measured; the measured number falls inside the stated range.
By their numbers in this assay, from the lowest: compounds 2 and 4 (each within the scatter of the next); then compound 1; then compound 3.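

In this assay the ring itself does not set the high number of compound 3: with cyclohexylamino, also a six-membered ring but of carbon only, the result is a 17-fold lower number from compound 3 to compound 4 (1.22 log units; beyond the scatter) (large), and the group also beats 3-hydroxypiperidin-1-yl with a 4.7-fold lower number from compound 1 to compound 4 (0.67 log units; beyond the scatter) (modest). Ring or open chain seems to matter little for this pair, since cyclohexylamino and diethylamino cannot be told apart (a 1.4-fold higher number from compound 2 to compound 4 (0.13 log units; within the scatter)), and among these four compounds none goes against the pattern that the two groups with a hetero atom beyond the nitrogen on the chain carbon, the hydroxyl of compound 1 and the second ring nitrogen of compound 3, give the higher numbers. Nothing available explains these differences.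

The compounds shown leave open whether that pattern would hold for plain piperidin-1-yl, which is the ring of compound 1 without its hydroxyl, or for morpholin-4-yl, which has a ring oxygen in place of the second nitrogen of piperazin-1-yl. They also leave open how much room this place allows for larger groups, such as a longer chain on the amine nitrogen or a benzylamino group.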